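Chromene ester series: N-methylation steps on the aryl amine

The source may hold more compounds than are shown below. What is called first, only, known or untested is meant among the compounds shown, and "the series" means these compounds.

Measured compounds in a functional assay on HL-60 cells (Homo sapiens) for cytotoxicity, read by CellTiter-Blue, with a stated time of 48 h; on this read-out higher numbers stand for weaker inhibition and lower numbers for stronger inhibition:
- compound 1, `C#CCOC(=O)CC1C(C(=O)OCC)=C(N)Oc2ccc(-c3cccc(N)c3)cc21`: 3400 nM
- compound 2, `C#CCOC(=O)CC1C(C(=O)OCC)=C(N)Oc2ccc(-c3cccc(NC)c3)cc21`: 7130 nM
- compound 3, `C#CCOC(=O)CC1C(C(=O)OCC#C)=C(N)Oc2ccc(-c3cccc(NC)c3)cc21`: 880 nM

Compound 3 gives the lowest number of the three measured compounds; the nearest is compound 1 and the furthest is compound 2, both steps beyond the scatter. Between compound 2 and compound 3 the ethynyl for methyl change gives an 8.1-fold lower number from compound 2 to compound 3 (0.91 log units; beyond the scatter).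

The change of interest is methyl in place of hydrogen on a nitrogen on an aromatic ring, which gave a 2.1-fold higher number from compound 1 to compound 2 (0.32 log units; beyond the scatter). The unmeasured compound 4, `C#CCOC(=O)CC1C(C(=O)OCC#C)=C(N)Oc2ccc(-c3cccc(N(C)C)c3)cc21`, carries the same kind of change relative to compound 3: methyl in place of hydrogen on a nitrogen on an aromatic ring. The two places are not the same word for word. In compound 1 the nitrogen's other neighbour is an aromatic carbon only; in compound 3 the nitrogen's other neighbours are an aromatic carbon and a saturated chain carbon, so the change reads methylamino to dimethylamino rather than amino to methylamino. The difference between the two cores of compound 1 and compound 3 is not broken down here.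

With one prior example only, and that at a different place, the expectation rests on compound 2 and its step of a 2.1-fold higher number from compound 1 to compound 2 (0.32 log units; beyond the scatter), taken as a guide for the size and direction. For compound 4 the expected step is a 2.0-fold higher number from compound 3 to compound 4 (0.31 log units; beyond the scatter) in this assay. Compound 4 is estimated at 1800 nM, with a range from 700 nM to 5000 nM.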

Compound 4, half-maximal inhibitory concentration: 12000 nM
Compound 4: middle estimate off by 6.7-fold (0.82 log units), on the low side; the whole stated range lies below it.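

In this assay methyl in place of hydrogen on the nitrogen, read here as methylamino to dimethylamino, gives a 14-fold higher number from compound 3 to compound 4 (1.13 log units; beyond the scatter). The number rises on both cores, but the size of the step does not carry over from one core to the other, so the earlier step gives the direction in these two pairs and not a usable magnitude: the same change on two cores in this assay, a 2.1-fold higher number (0.32 log units; beyond the scatter) from compound 1 to compound 2 and a 14-fold higher number (1.13 log units; beyond the scatter) from compound 3 to compound 4, 6.5-fold (0.81 log units) apart, beyond the scatter of two such steps. Within the data shown here, this does not show which structural difference sets the size of the step, since the two pairs differ both in the starting group on the nitrogen, amino against methylamino, and in the ethynyl for methyl change elsewhere in the molecule; with only two pairs, it also gives no general rule for the series.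

The compounds shown leave open how amino to methylamino behaves on the core of compound 3 and how methylamino to dimethylamino behaves on the core of compound 1, the two comparisons that would separate these differences. Also open, going by these compounds, is how the series responds when the aromatic nitrogen carries an ethyl group, an acetyl group or a pyrrolidine ring.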